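Adding a single fluorine to the benzoyl ring of compound 3

The source may hold more compounds than are shown below. What is called first, only, known or untested is meant among the compounds shown, and "the series" means these compounds.

Compound 3 `CC1(C)S[C@@H]2/C(=C\C(=O)c3ccccc3)C(=O)N2[C@H]1C(=O)OC(c1ccccc1)c1ccccc1` stands second highest among three numbers in a functional assay on A-375 cells (Homo sapiens) for cytotoxicity, read by MTT assay, with a stated time of 48 h; on this read-out lower numbers stand for stronger inhibition and higher numbers for weaker inhibition. Compound 1 `CC1(C)S[C@@H]2/C(=C\C(=O)c3cc(F)cc(F)c3)C(=O)N2[C@H]1C(=O)OC(c1ccccc1)c1ccccc1` gives 19100 nM in this assay, and compound 3 gives 22800 nM, while compound 2 `CC1(C)[C@H](C(=O)OC(c2ccccc2)c2ccccc2)N2C(=O)/C(=C/C(=O)c3ccc([N+](=O)[O-])cc3)[C@H]2[S+]1[O-]`, built on a different core, gives 48200 nM. Compound 4 `CC1(C)S[C@@H]2/C(=C\C(=O)c3ccc(F)cc3)C(=O)N2[C@H]1C(=O)OC(c1ccccc1)c1ccccc1` is the next step: fluoro in place of hydrogen on an aromatic carbon, so the benzoyl becomes a (4-fluorophenyl)carbonyl. For the measured compounds named here, the one step that bears on it is a 1.2-fold higher number from compound 1 to compound 3 (0.08 log units; within the scatter), where removing two fluorines from the same ring left the number within the scatter. A single fluorine entering is therefore expected to give a 1.1-fold lower number from compound 3 to compound 4 (0.04 log units; within the scatter), no movement beyond the scatter in either direction. The estimate for compound 4 in this assay is 21000 nM, within a range of 10000 nM to 45000 nM.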

Compound 4, half-maximal inhibitory concentration: 17800 nM
Beside the measured number, compound 4's estimate is 1.2-fold (0.07 log units) above it; low and high end bracket the measured number.
By their numbers in this assay, from the lowest: compounds 4, 1 and 3 (each within the scatter of the next); then compound 2.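

In this assay a single fluoro on the aromatic carbon para to a large group gives a 1.3-fold lower number from compound 3 to compound 4 (0.11 log units; within the scatter) and so leaves the number within the scatter. Swapping the 3,5-difluorophenyl for the 4-fluorophenyl gives a 1.1-fold lower number from compound 1 to compound 4 (0.03 log units; within the scatter) and also stays within the scatter, so the phenyl, 4-fluorophenyl and 3,5-difluorophenyl compounds cannot be told apart here. Nothing available explains why these fluorine changes have so little effect. As far as these compounds go, whether a larger or charged group at this place, such as an amine or a carboxylic acid, would shift the number beyond the scatter remains open.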